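This account rests on a few compounds, and the source may have more. Where it says the series, first, only, none or still open, it means among the compounds named here.

Compound 1 `CC(C)=CC[C@@H](OC[C@H](C)O)C1=CC(=O)c2c(O)ccc(O)c2C1=O` is one of three compounds that share a core and differ only in the group carried on an oxygen on a saturated carbon. In a functional assay on HeLa cells (Homo sapiens) for cytotoxicity, read by MTT assay (a lower number here means a stronger inhibitor, a higher number a weaker inhibitor), compound 1 gives 40300 nM, the lowest of the three numbers, though the gap to either neighbour is within the scatter. Compound 2 `CCCCC(C)(O)CC(=O)O[C@H](CC=C(C)C)C1=CC(=O)c2c(O)ccc(O)c2C1=O` gives 60600 nM and compound 3 `CC(C)=CC[C@@H](OC(=O)C1CCCOC1)C1=CC(=O)c2c(O)ccc(O)c2C1=O` gives 60500 nM; the steps of a 1.5-fold higher number from compound 1 to compound 2 (0.18 log units; within the scatter) and a 1.5-fold higher number from compound 1 to compound 3 (0.18 log units; within the scatter) are both small, as is a 1.0-fold lower number from compound 2 to compound 3 (0.00 log units; within the scatter).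

Compound 4 `CCC(CO[C@H](CC=C(C)C)C1=CC(=O)c2c(O)ccc(O)c2C1=O)OC` has not yet been measured. It differs from compound 1 in that (1-methoxypropyl in place of 1-hydroxyethyl on a saturated chain carbon bound to an oxygen on a saturated carbon). Going by the values given here, the only steps that bear on this change are the two from compound 1, in which a quite different group took the same place on that oxygen without moving the number beyond the scatter. Compound 4 is therefore expected to show no step beyond the scatter, with a 1.1-fold higher number from compound 1 to compound 4 (0.05 log units; within the scatter) as the estimated change. Compound 4 is estimated to give 45000 nM, in a range from 20000 nM to 100000 nM.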

Compound 4, half-maximal inhibitory concentration: 63500 nM
Compound 4: the middle estimate sits 1.4-fold (0.15 log units) below what was measured; the measured number falls inside the stated range.
By their numbers in this assay, from the lowest: compounds 1, 3, 2 and 4 (each within the scatter of the next).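

In this assay, exchanging 1-hydroxyethyl, which carries a hydrogen-bond donor, for the larger 1-methoxypropyl, which carries none, comes with a 1.6-fold higher number from compound 1 to compound 4 (0.20 log units; within the scatter), so at this position neither the loss of that donor nor the added size moves the number beyond the scatter. The 2-methoxybutyl group is also not separated from the two groups attached through a carbonyl, with a 1.0-fold higher number from compound 3 to compound 4 (0.02 log units; within the scatter) and a 1.0-fold higher number from compound 2 to compound 4 (0.02 log units; within the scatter). Nothing available explains why these exchanges leave the number within the scatter.

On these data alone, it remains open whether an amine or a carboxylic acid at this place, or a much longer chain, would take the number beyond the scatter. Also open, as far as these compounds go, is whether the defined stereocentre of 1-hydroxyethyl matters, since 1-methoxypropyl has none.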